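The source may hold more compounds than are shown below. What is called first, only, known or untested is meant among the compounds shown, and "the series" means these compounds.

Of the compounds shown here, three built on one shared core have been tested in a functional assay on A549 cells (Homo sapiens) for cytotoxicity, read by MTT assay, with a stated time of 24 h; a lower number here means a stronger inhibitor, a higher number a weaker inhibitor. Compound 2 `COC(=O)[C@@H](C)NC(=O)Cn1cc(C2=C(c3c[nH]c4ccccc34)C(=O)N(C)C2=O)c2ccccc21` gives 30500 nM, the lowest of the two numbers shown. Compound 3 `COC(=O)C[C@@H](NC(=O)Cn1cc(C2=C(c3c[nH]c4ccccc34)C(=O)N(C)C2=O)c2ccccc21)C(=O)OC` gives 74200 nM. Compound 1 `COC(=O)[C@@H](CC(C)C)NC(=O)Cn1cc(C2=C(c3c[nH]c4ccccc34)C(=O)N(C)C2=O)c2ccccc21` reports only a limit of this assay, > 100000 nM. Compound 4 `COC(=O)[C@H](NC(=O)Cn1cc(C2=C(c3c[nH]c4ccccc34)C(=O)N(C)C2=O)c2ccccc21)[C@@H](C)O` differs from compound 2 by 1-hydroxyethyl in place of methyl on a saturated chain carbon bound to an amide-type nitrogen and a carbonyl carbon. Two measured steps speak to this change: the step of an at least 3.2-fold lower number from compound 1 to compound 2 (0.51 log units; beyond the scatter) and the step of a 2.4-fold higher number from compound 2 to compound 3 (0.39 log units; beyond the scatter), each showing that a larger group at that part of the molecule went with a higher number. Compound 4 is therefore expected to sit modestly higher than compound 2, by a 1.8-fold higher number from compound 2 to compound 4 (0.26 log units; within the scatter). Compound 4 is estimated at 55000 nM, within a range from 22000 nM to 140000 nM.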

Compound 4, half-maximal inhibitory concentration: 25700 nM
Beside the measured number, compound 4's estimate is 2.1-fold (0.33 log units) above it; the measured number falls inside the stated range.
By their numbers in this assay, from the lowest: compounds 4 and 2 (each within the scatter of the next); then compound 3. At a limit, above all of these: compound 1.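

Putting 1-hydroxyethyl in place of methyl on this saturated chain carbon gives no real change, a 1.2-fold lower number from compound 2 to compound 4 (0.07 log units; within the scatter), so a larger group here need not go with a higher number. The same group does stand apart from (methoxycarbonyl)methyl, a 2.9-fold lower number from compound 3 to compound 4 (0.46 log units; beyond the scatter), and from isobutyl, an at least 3.8-fold lower number from compound 1 to compound 4 (0.59 log units; beyond the scatter). That last step rests on compound 1, which gives only a limit: the limit of > 100000 nM in this assay, at which 1 of the 4 values shown sits.

Still open, from the compounds shown here alone, is whether the hydroxyl of 1-hydroxyethyl matters, which a compound with a plain isopropyl group at this carbon could test. Also open, going by these compounds, is how an amine or a carboxylic acid would read here.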